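Fluoro in Place of Methyl: From Compound 1 to Compound 3

The source may hold more compounds than are shown below. What is called first, only, known or untested is meant among the compounds shown, and "the series" means these compounds.

Compound 1 `Cc1cccc(S(=O)(=O)c2ccc(CNC(=O)c3cc4cnccc4[nH]3)cc2)c1`: 8 nM
Compound 2 `O=C(NCc1ccc(S(=O)(=O)c2cccc(C(F)(F)F)c2)cc1)c1cnc2nccn2c1`: 1 nM

Of the compounds shown here, two have been measured in an assay for inhibition of Nicotinamide phosphoribosyltransferase (Homo sapiens), read by mass spectrometry, with stated times of 15 min and 30 min; on this read-out lower numbers stand for stronger inhibition and higher numbers for weaker inhibition. Compound 1 gives 8 nM and stands with the higher of the two numbers; the nearest, compound 2, gives 1 nM, a lower number by a margin beyond the scatter. The two differ in more than one place, so their values are set side by side without any single change being credited for the gap.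

The unmeasured compound 3 `O=C(NCc1ccc(S(=O)(=O)c2cccc(F)c2)cc1)c1cc2cnccc2[nH]1` keeps the core of compound 1 and changes one thing: fluoro in place of methyl on an aromatic carbon. A swap of one single-atom substituent for another at the same place on the ring gives little ground, from the compounds shown, to expect a large shift in this assay in either direction. Compound 3 is therefore expected to land close to compound 1, with a step of a 1.3-fold higher number from compound 1 to compound 3 (0.10 log units; within the scatter) that stays within the scatter. The estimate for compound 3 in this assay is 10 nM, with a range from 3 nM to 35 nM.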

Compound 3, half-maximal inhibitory concentration: 5 nM
Estimate against measurement, compound 3: 2.0-fold (0.30 log units) above, and the stated range covers the measured number.
By their numbers in this assay, from the lowest: compound 2; then compounds 3 and 1 (each within the scatter of the next).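

In this assay, the exchange of 3-methylphenyl for 3-fluorophenyl gives a 1.6-fold lower number from compound 1 to compound 3 (0.20 log units; within the scatter), so at this place on the ring, fluoro in place of methyl leaves the read-out within the usual scatter. The earlier pair could not show this, since compound 1 and compound 2 differ in more than one place and no part of the gap between them could be credited to a single change, whereas this step isolates one substituent on an aromatic carbon and shows that the two single-atom groups cannot be told apart here. Nothing among the data shown explains why the exchange leaves the number within the scatter.

On these data alone, two single-atom substituents say little about how far this place on the ring can be changed, so it remains open how an amine, a carboxylic acid, a methoxy group or a longer chain would read there, or how the ring would read with a plain hydrogen in that place. The lower number of compound 2 also remains unassigned, as compound 2 differs from compound 3 in more than one place and its trifluoromethyl group cannot be judged apart from its other differences.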